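From Phenyl to Cyclohexyl: What Should Happen Next?

A few compounds are considered here, and "the series" means these few. Any claim that something is new, unique, unknown or untested is made for them only; others in the source may bear on it.

Compound 1 `C/C(=N\NC(N)=S)c1ccc2[nH]c(-c3ccccc3)nc2c1` is the starting point. In an ADME assay on MDBK cells (Bos taurus) for cytotoxicity, read by MTT assay, with a stated time of 96 h (a higher number here means that more compound is tolerated, a lower number that less compound is tolerated), compound 1 gives 32000 nM. Compound 3 `C/C(=N\NC(N)=S)c1ccc2c(c1)nc(-c1ccccc1)n2C1CCCCC1` gives 24000 nM, which lies within the usual scatter of compound 1, so these two share the upper end of the measured range. Compound 2 `C/C(=N\NC(N)=S)c1ccc2[nH]c(-c3ccc(C(F)(F)F)cc3)nc2c1` gives 5000 nM, clearly apart from that pair.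

Compound 4 `C/C(=N\NC(N)=S)c1ccc2[nH]c(C3CCCCC3)nc2c1` keeps the core of compound 1 and alters one group: cyclohexyl in place of phenyl on an aromatic carbon. In words, cyclohexyl stands in place of phenyl on an aromatic carbon, between two ring nitrogen atoms.

Going by the values given here, no measured step makes this exact swap, but two bear on it. Trifluoromethyl in place of hydrogen on an aromatic carbon gave a 6.4-fold lower number from compound 1 to compound 2 (0.81 log units; beyond the scatter), which shows that a change to the phenyl group can move the number in this assay. Cyclohexyl in place of hydrogen on an aromatic nitrogen gave a 1.3-fold lower number from compound 1 to compound 3 (0.12 log units; within the scatter), which shows that a cyclohexyl group elsewhere on the core need not move it. Weighing the two, no step beyond the scatter is expected, with a slight lean towards a lower number. The estimate for compound 4 is 22000 nM, with an expected range of 8000 nM to 55000 nM. This estimate amounts to an expected 1.5-fold lower number from compound 1 to compound 4 (0.16 log units; within the scatter).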

Compound 4, half-maximal cytotoxic concentration: > 100000 nM
Compound 4: only a limit was reported (the forecaster's own chance of this, stated with the estimate: 10%); middle value at least 4.5-fold (0.65 log units) from the limit.
By their numbers in this assay, from the lowest: compound 2; then compounds 3 and 1 (each within the scatter of the next). At a limit, above all of these: compound 4.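

Compound 4 gives > 100000 nM in this assay, and this value is a limit of the assay, not a number. Cyclohexyl in place of phenyl on an aromatic carbon, between two ring nitrogen atoms, gives an at least 3.1-fold higher number from compound 1 to compound 4 (0.49 log units; beyond the scatter), so a change at this position can raise the tolerated concentration, whereas the one earlier change on the phenyl group gave a 6.4-fold lower number from compound 1 to compound 2 (0.81 log units; beyond the scatter). The entering and leaving groups have the same count of heavy atoms and differ in an aromatic versus a non-aromatic ring, while cyclohexyl in place of hydrogen on an aromatic nitrogen gave a 1.3-fold lower number from compound 1 to compound 3 (0.12 log units; within the scatter), so among these compounds the place of the cyclohexyl group matters.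

On these data alone, the full size of the step from phenyl to cyclohexyl stays open, as the reading for compound 4 gives only a lower bound: the limit of > 100000 nM in this assay, at which 1 of the 4 values shown sits. It is also open whether cyclopentyl, a piperidine ring or a straight hexyl chain on this same carbon would behave like cyclohexyl or like phenyl, and so whether the non-aromatic ring itself is what matters.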